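A few compounds are considered here, and "the series" means these few. Any claim that something is new, unique, unknown or untested is made for them only; others in the source may bear on it.

In a functional assay on MCF7 cells (Homo sapiens) for antiproliferative activity, with a stated time of 72 h (on this read-out higher numbers stand for weaker inhibition and lower numbers for stronger inhibition), compound 3 (`C=C1C=CC(=O)[C@@H]2[C@H](Cc3ccccc3)CC[C@H]12`) gives 260 nM as the highest number of the three measured. Compound 1 (`C=C1C=CC(=O)[C@@H]2[C@H](Cc3ccc(OCOC)cc3)CC[C@H]12`) gives 63.6 nM and compound 2 (`C=C1C=CC(=O)[C@@H]2[C@H](Cc3ccc(OCOC)c(F)c3)CC[C@H]12`) gives 77.2 nM in the same read-out. Compound 4 (`C=C1C=CC(=O)[C@@H]2[C@H](Cc3ccc(O)cc3)CC[C@H]12`) differs from compound 3 by one change (hydroxy in place of hydrogen on an aromatic carbon): hydroxy in place of hydrogen on an aromatic carbon, para to a large group. The fluoro step (a 1.2-fold higher number from compound 1 to compound 2 (0.08 log units; within the scatter)) stays within the scatter and bears little on this change. For the measured compounds named here, compound 1 bears most: hydrogen in place of methoxymethoxy (a 4.1-fold higher number from compound 1 to compound 3 (0.61 log units; beyond the scatter)) lies beyond the scatter, so a modest step to a lower number in this assay is expected, though no measured compound carries hydroxy. The estimated step is modest (a 2.4-fold lower number from compound 3 to compound 4 (0.37 log units; beyond the scatter)). For compound 4 the estimate is 110 nM (range 45 nM to 270 nM).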

Compound 4, half-maximal inhibitory concentration: 33.8 nM
Beside the measured number, compound 4's estimate is 3.3-fold (0.51 log units) above it; the whole stated range lies above it.
By their numbers in this assay, from the lowest: compounds 4, 1 and 2 (each within the scatter of the next, the first and the last beyond it); then compound 3.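

In this assay, hydroxy in place of hydrogen on this aromatic carbon, para to a large group, gives a clear step (a 7.7-fold lower number from compound 3 to compound 4 (0.89 log units; beyond the scatter)), so the oxygen substituent need not carry a methoxymethyl cap to reach the range of compound 1. Hydrogen in place of methoxymethyl on that oxygen gives a step within the scatter (a 1.9-fold lower number from compound 1 to compound 4 (0.27 log units; within the scatter)), so compound 1 and compound 4 cannot be ordered. No available evidence accounts for either step.

Going by these compounds, whether an amine or a carboxylic acid at this place would match hydroxy remains open. Also open, on these data alone, is whether fluoro on the ring of compound 4 would stay within the scatter, as it does for compound 1.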